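A few compounds are considered here, and "the series" means these few. Any claim that something is new, unique, unknown or untested is made for them only; others in the source may bear on it.

Compound 1 `COC/C1=C/C[C@](C)(CCC=C(C)C)/C=C/[C@@H](OC(=O)C=C(C)C)[C@](C)(O)/C=C/C1=O`: 4130 nM
Compound 2 `C=C1/C=C/C(=O)/C(CO)=C\C[C@](C)(CCC=C(C)C)/C=C/[C@H]1OC(=O)C=C(C)C`: 2750 nM

In a functional assay on MCF7 cells (Homo sapiens) for antiproliferative activity, read by MTT assay, with a stated time of 48 h (on this read-out higher numbers stand for weaker inhibition and lower numbers for stronger inhibition), compound 1 and compound 2 lie within the usual scatter of each other, so the two cannot be ranked. Compound 3 `CC(C)=CCC[C@]1(C)/C=C/[C@@H](OC(=O)C=C(C)C)[C@](C)(O)/C=C/C(=O)/C(CN2CCCC2)=C\C1` keeps the core of compound 1 but carries pyrrolidin-1-yl in place of methoxy on a saturated chain carbon bound to a double-bonded ring carbon. Among the compounds with values here, no measured pair shows what this kind of change does, so the only starting point is compound 1 at 4130 nM. The estimated change is a 1.4-fold lower number from compound 1 to compound 3 (0.14 log units; within the scatter), so no step beyond the scatter is expected in this assay. For compound 3 the expected value is 3000 nM, with an estimated range of 1000 nM to 9000 nM.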

Compound 3, half-maximal inhibitory concentration: 220 nM
Compound 3: middle estimate off by 14-fold (1.13 log units), on the high side; the measured number lies below the stated range.
By their numbers in this assay, from the lowest: compound 3; then compounds 2 and 1 (each within the scatter of the next).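

In this assay, putting pyrrolidin-1-yl in place of methoxy on a saturated chain carbon bound to a double-bonded ring carbon gives a 19-fold lower number from compound 1 to compound 3 (1.27 log units; beyond the scatter) and so a large step beyond the scatter. Within the data shown here, this shows that the number responds strongly to the group at this place, which the earlier compounds could not show because they offered no step there. Nothing here indicates why the number drops. Still open, on these data alone, is whether the ring or the nitrogen matters more: dimethylamino, an open-chain amine, or morpholin-4-yl, a ring with a second hetero atom, would help separate the two.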